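The compounds below may be only part of what the source reports. "The series", "measured", "known", "first", "only" and "open" are said of these compounds alone.

Series in a functional assay on A549 cells (Homo sapiens) for antiproliferative activity, read by MTT assay; on this read-out higher numbers stand for weaker inhibition and lower numbers for stronger inhibition:
- compound 1 `Cn1c(=O)c(=O)n(C2CCCC2)c2nc(N/N=C/c3ccccc3)ncc21`: > 100000 nM
- compound 2 `Cn1c(=O)c(=O)n(C2CCCC2)c2nc(N/N=C/c3ccc(S(C)(=O)=O)cc3)ncc21`: 84500 nM
- compound 3 `Cn1c(=O)c(=O)n(C2CCCC2)c2nc(N/N=C/c3cccc(Cl)c3Cl)ncc21`: 39100 nM

The entry for compound 1 is a limit of the assay, not a number. Going by the values given here, of the two true numbers, compound 3 holds the lower one, and compound 2 is its only numerical neighbour.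

The next compound is compound 4 `Cc1cc(C)c(/C=N/Nc2ncc3c(n2)n(C2CCCC2)c(=O)c(=O)n3C)c(C)c1`, with 2,4,6-trimethylphenyl in place of 2,3-dichlorophenyl on a carbon with a double bond to nitrogen. This puts 2,4,6-trimethylphenyl in place of 2,3-dichlorophenyl on a carbon with a double bond to nitrogen.

Among the compounds with values here, no measured compound carries the entering group, so the guide is the size of the steps at this same aromatic group. These are an at least 1.1-fold lower number from compound 1 to compound 2 (0.07 log units; that floor lies within the scatter), an at least 2.5-fold lower number from compound 1 to compound 3 (0.40 log units; beyond the scatter) and a 2.2-fold lower number from compound 2 to compound 3 (0.33 log units; beyond the scatter). All are small, and the first two rest on a limit. A similarly small step is therefore expected in this assay, with a slight lean towards a higher number, as compound 3 is the lowest so far at 39100 nM.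

The expected change is a 1.3-fold higher number from compound 3 to compound 4 (0.11 log units; within the scatter).

Compound 4 is estimated at 50000 nM, with an expected range of 22000 nM to 100000 nM.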

Compound 4, half-maximal inhibitory concentration: 12000 nM
Estimate against measurement, compound 4: 4.2-fold (0.62 log units) above; the measured number lies below the stated range.
By their numbers in this assay, from the lowest: compound 4; then compound 3; then compound 2. At a limit, above all of these: compound 1.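

In this assay, going by these compounds alone, the aromatic group on the carbon with a double bond to nitrogen proves able to shift the number by more than the earlier compounds showed, with a 3.3-fold lower number from compound 3 to compound 4 (0.51 log units; beyond the scatter) and a 7.0-fold lower number from compound 2 to compound 4 (0.85 log units; beyond the scatter), and compound 4 now stands lowest of the series, its steps to all others being beyond the scatter. The change removes both chlorine atoms and adds three methyl groups, so a ring carrying only carbon substituents reads lower here than the chlorinated ring of compound 3 or the methylsulfonyl ring of compound 2. The comparison with the unsubstituted phenyl, an at least 8.3-fold lower number from compound 1 to compound 4 (0.92 log units; beyond the scatter), gives only a floor, and compound 1 stands at a limit: the limit of > 100000 nM in this assay, at which 1 of the 4 values shown sits.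

Open, on these data alone, is whether the lower number needs all three methyl groups or follows from fewer. Also open, as far as these compounds go, is how a methoxy group, an amine or a carboxylic acid on this ring would read, or a pyridine ring in its place.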